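The source may hold more compounds than are shown below. What is called first, only, known or untested is meant among the compounds shown, and "the series" means these compounds.

Series notes, cytotoxicity on liver-derived cells.

Compound 1 `FC(F)(Cl)C(F)(Cl)CCSc1nc2ccc(Cl)cc2s1` is recorded in a functional assay on HepG2 cells (Homo sapiens) for cytotoxicity, read by MTT assay, with a stated time of 48 h (a higher number here means a weaker inhibitor, a lower number a stronger inhibitor), only as a limit, at > 120000 nM. Compound 2 `FC(F)=C(F)CCSc1nc2ccccc2[nH]1` likewise gives no number in this assay, only the limit > 120000 nM. Within the data shown here, compound 3 `CC(=C(C#N)C#N)c1nccs1`, built on a different core, is the one member with a finite reading, 105000 nM in this assay. Compound 2 therefore stands where most of the series stands, at the limit of > 120000 nM in this assay, at which 2 of the 3 values shown sit, with no ranking possible against compound 1 and only a weak contrast with compound 3.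

Compound 4 `FC(F)=C(F)CCSc1nc2ccc(OC(F)F)cc2[nH]1` is the next step from compound 2: difluoromethoxy in place of hydrogen on an aromatic carbon. Among the measured compounds shown here, no measured pair carries a comparable change, so there is no precedent for its size or direction. The starting point is itself a limit, and the step is expected to leave the value within the scatter of that limit, with no shift beyond it in this assay. The estimate for compound 4 in this assay is 130000 nM, range 60000 nM to 300000 nM, which as a step is expected to be a step that the limit leaves unreadable from compound 2 to compound 4.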

Compound 4, half-maximal inhibitory concentration: > 120000 nM
Compound 4: only a limit was reported; the forecaster's own chance of this, stated with the estimate: 75%; the middle value does not contradict the limit.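

Compound 2 and compound 4 are both recorded only as limits in this assay, so no step can be read between them: the limit of > 120000 nM in this assay, at which 3 of the 4 values shown sit.

The compounds shown leave open whether difluoromethoxy in place of hydrogen changes the reading at all, and how compound 2 and compound 4 rank.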